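This account rests on a few compounds, and the source may have more. Where it says the series, first, only, none or still open, it means among the compounds named here.

Compound 1 `CC(O)(C[S+]([O-])c1ccc(F)cc1F)C(=O)Nc1ccc([N+](=O)[O-])cc1C(F)(F)F` gives > 100000 nM in a functional assay on VCaP cells (Homo sapiens) for antiproliferative activity (a lower number here means a stronger inhibitor, a higher number a weaker inhibitor), which is a limit of the assay and not a number. Compound 2 `CC(O)(C[S+]([O-])c1ccc(OC(F)(F)F)cc1)C(=O)Nc1ccc(C#N)c(C(F)(F)F)c1` gives 53500 nM in this assay. Compound 3 `CC(O)(C[S+]([O-])c1ccc(C(F)(F)F)cn1)C(=O)Nc1ccc(C#N)c(C(F)(F)F)c1` gives > 100000 nM; > 100000 nM (2 entries) in this assay, both entries being limits.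

Compound 1 therefore stands at the edge of what this assay can report: it is known only as a limit, namely (the limit of > 100000 nM in this assay, at which 1 of the 3 values shown sits). Compound 4 `CC(O)(C[S+]([O-])c1ccccn1)C(=O)Nc1ccc([N+](=O)[O-])cc1C(F)(F)F` differs from it by pyridin-2-yl in place of 2,4-difluorophenyl on a sulfur. Within the data shown here, no two compounds here differ in a single place, so no measured step guides this change. Compound 4 is expected to stay in the same weak region, so the step of a number no higher from compound 1 to compound 4 (the limit leaves the size open) is estimated to be no larger than the scatter. Compound 4 is expected to give about 100000 nM in this assay, between 30000 nM and 300000 nM.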

Compound 4, half-maximal inhibitory concentration: 100000 nM
Estimate against measurement, compound 4: no gap at the digits printed; low and high end bracket the measured number.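

Pyridin-2-yl in place of 2,4-difluorophenyl on a sulfur gives a number no higher from compound 1 to compound 4 (the limit leaves the size open), the first step at this position. The change brings no clear gain in this assay, since compound 4 gives 100000 nM, so the ring nitrogen alone does not lift this core out of the weak region. Compound 1 is known only as a limit of the assay: the limit of > 100000 nM in this assay, at which 1 of the 4 values shown sits.

The compounds shown leave open how far the true gap between these two compounds extends. They also leave open how an amine or a carboxylic acid on this ring, or a saturated chain in its place on the sulfur, would read in this assay.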